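This account rests on a few compounds, and the source may have more. Where it says the series, first, only, none or still open, it means among the compounds named here.

The series is judged in an in vitro functional assay on HEK293 cells for antagonist activity at melanin-concentrating hormone receptor 1 (Homo sapiens); a higher number here means a larger maximal response, a lower number a smaller maximal response. Compound 1 `CC(=O)OCC(C)(C)NC(=O)N(CCC1CCN(Cc2ccc(C)cc2)CC1)Cc1ccc(-c2ccccc2)cc1` gives 102% there, while compound 2 `Cc1ccc(CN2CCC(CCN(Cc3ccc(-c4cccc(C#N)c4)cc3)C(=O)NC(C)(C)CO)CC2)cc1` gives 99.3% in this assay, a number that sits within the usual scatter of the value of compound 1, so the two measured compounds cannot be told apart on this read-out. For the measured compounds named here, no step between measured compounds has been worked out for this pair, and what the two values show is simply that both reach essentially the full maximal response.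

Compound 3 `Cc1ccc(CN2CCC(CCN(Cc3ccc(-c4ccccc4)cc3)C(=O)NC(C)(C)CO)CC2)cc1` differs from compound 2 in one place: hydrogen in place of cyano on an aromatic carbon. Because compound 2 already gives 99.3% and compound 1 gives 102%, the step expected from compound 2 to compound 3 in this assay is a number 0.7 percentage points higher from compound 2 to compound 3 (within the scatter), none beyond the scatter. Compound 3 is therefore expected to reach a maximal response of about 100%, with a likely range from 90% to 110%.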

Compound 3, largest response reached (reported as Imax), in percent of the reference or control that the assay uses: 105%
Beside the measured number, compound 3's estimate is 5 percentage points below it, and the stated range covers the measured number.
By their numbers in this assay, from the lowest: compounds 2, 1 and 3 (each within the scatter of the next).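

In this assay, the exchange of 3-cyanophenyl for phenyl gives a number 5.7 percentage points higher from compound 2 to compound 3 (within the scatter), so at this place on the aromatic ring the nitrile cannot be told apart from hydrogen on this read-out. The second step, hydrogen in place of acetyl on the oxygen, gives a number 3 percentage points higher from compound 1 to compound 3 (within the scatter), so the acetyl on that oxygen cannot be told apart from hydrogen either. No measurement at hand explains either result.

The compounds shown leave open whether another group at the same place on the aromatic ring, such as an amine or a carboxylic acid, would also stay within the scatter of compound 3. They also leave open whether a longer chain on the oxygen, such as a butanoyl group in place of acetyl, would do the same.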